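The source may hold more compounds than are shown below. What is called first, only, known or untested is meant among the compounds shown, and "the series" means these compounds.

Working notes on the series. In a functional assay on NCI-H460 cells (Homo sapiens) for cytotoxicity, read by MTT assay, with a stated time of 72 h (on this read-out higher numbers stand for weaker inhibition and lower numbers for stronger inhibition), compound 3 `CN(C)Cc1ccc2nc(NC(=O)N/N=C/c3cn(Cc4ccccc4)c4ccccc34)sc2c1` gives 400 nM, which is within the scatter of compound 2 `CCN(CC)Cc1ccc2nc(NC(=O)N/N=C/c3cn(Cc4ccc(C)cc4)c4ccccc34)sc2c1` at 320 nM. Compound 1 `CCN(CC)Cc1ccc2nc(NC(=O)N/N=C/c3cn(Cc4ccc(C(C)(C)C)cc4)c4ccccc34)sc2c1` lies clearly higher at 1670 nM.

The next compound is compound 4 `CCN(CC)Cc1ccc2nc(NC(=O)N/N=C/c3cn(Cc4ccccc4)c4ccccc34)sc2c1`, with the change (diethylamino in place of dimethylamino on a saturated chain carbon bound to an aromatic carbon), in words diethylamino in place of dimethylamino on a saturated chain carbon bound to an aromatic carbon. Among the compounds with values here, no measured step covers this change. Within the data shown here, the one step available, a 5.2-fold lower number from compound 1 to compound 2 (0.72 log units; beyond the scatter), is modest and comes from methyl in place of tert-butyl on an aromatic carbon, so it gives no direct size for this change.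

The nearest evidence is compound 2, which already carries diethylamino and gives 320 nM, within the scatter of compound 3. No step beyond the scatter is therefore expected in this assay, and no direction is favoured. The estimated step is a 1.1-fold lower number from compound 3 to compound 4 (0.03 log units; within the scatter). Compound 4 is expected at 370 nM, with an estimated range of 170 nM to 800 nM.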

Compound 4, half-maximal inhibitory concentration: 450 nM
Estimate against measurement, compound 4: 1.2-fold (0.09 log units) below; the measured number falls inside the stated range.
By their numbers in this assay, from the lowest: compounds 2, 3 and 4 (each within the scatter of the next); then compound 1.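

Diethylamino in place of dimethylamino on a saturated chain carbon bound to an aromatic carbon gives in this assay a 1.1-fold higher number from compound 3 to compound 4 (0.05 log units; within the scatter) and so leaves the number within the scatter, which compound 2 could only suggest. With diethylamino held constant, hydrogen in place of methyl on an aromatic carbon gives a 1.4-fold higher number from compound 2 to compound 4 (0.15 log units; within the scatter) and stays within the scatter, while hydrogen in place of tert-butyl gives a 3.7-fold lower number from compound 1 to compound 4 (0.57 log units; beyond the scatter) and so sets compound 1 apart from compound 4 as well as from compound 2. No measurement shown bears on a cause for these steps.

Open is whether morpholine or a longer chain such as dipropylamino in place of diethylamino stays within the scatter of these compounds. Also open, as far as these compounds go, is how chlorine or methoxy on that aromatic carbon compares with methyl and tert-butyl.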